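Trimming the Chain Down to a Phenoxy Group

The compounds below may be only part of what the source reports. "The series", "measured", "known", "first", "only" and "open" are said of these compounds alone.

Measured compounds, in a functional assay on CHO cells for agonist activity at prostaglandin E2 receptor EP1 subtype (Homo sapiens), read by fluorescence and calcium flux; on this read-out lower numbers stand for an effect already at smaller amounts and higher numbers for an effect only at larger amounts of compound:
- compound 1 `O=C(O)c1csc([C@H]2CC[C@@H]3[C@@H](/C=C/COc4ccccc4)[C@H](O)C[C@@H]3O2)n1`: compound 1 gives 700 nM
- compound 2 `O=C(O)c1csc([C@H]2CC[C@@H]3[C@@H](/C=C/CCCOc4ccccc4)[C@H](O)C[C@@H]3O2)n1`: compound 2 gives 970 nM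
- compound 3 `O=C(O)c1csc([C@H]2CC[C@@H]3[C@@H](CCCCCOc4ccccc4)[C@H](O)C[C@@H]3O2)n1`: compound 3 gives "not determined" (no result reported) in this assay

Compound 1 differs from compound 2 by phenoxy in place of 2-phenoxyethyl on a saturated chain carbon bound to a double-bonded chain carbon, and this change made a 1.4-fold lower number from compound 2 to compound 1 (0.14 log units; within the scatter). Compound 4 `O=C(O)c1csc([C@H]2CC[C@@H]3[C@@H](CCCOc4ccccc4)[C@H](O)C[C@@H]3O2)n1` relates to compound 3 through the same kind of change, (phenoxy in place of 2-phenoxyethyl on a saturated chain carbon, three bonds along the chain from a saturated ring carbon); the surroundings of the place differ, three bonds along the chain from a saturated ring carbon in one pair and bound to a double-bonded chain carbon in the other. The difference between the core of compound 3 and the core of compound 2 is not broken down here. Since compound 3 has no number, the expectation for compound 4 rests on compound 2 with 970 nM and on the small step of a 1.4-fold lower number from compound 2 to compound 1 (0.14 log units; within the scatter). Compound 4 is therefore expected to give about 900 nM, estimated to fall between 250 nM and 3500 nM.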

Compound 4, half-maximal effective concentration: 4200 nM
The estimate for compound 4 lay 4.7-fold (0.67 log units) below the measured number, outside the stated range (above it).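

Going by these compounds alone, no step from compound 3 to compound 4 can be read in this assay, where compound 3 has no single number. The compounds shown leave open how trimming to phenoxy acts on the saturated chain. Nothing available explains the result of compound 4.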